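The compounds below may be only part of what the source reports. "The series", "measured", "known", "first", "only" and "open" are said of these compounds alone.

Measured compounds:
- Compound 1 `CCN1CCN(Cc2c(OC)cc(Oc3cccc(Nc4ccccc4)c3)cc2OC)CC1`. In a functional assay on HCT-116 cells (Homo sapiens) for inhibition, read by MTT assay, with a stated time of 72 h (on this read-out lower numbers stand for stronger inhibition and higher numbers for weaker inhibition), compound 1 gives > 20000 nM, which is a limit of the assay and not a number.
- Compound 2 `CNCc1c(OC)cc(Oc2cccc(Nc3ccccc3)c2)cc1OC`. Compound 2 gives > 20000 nM, again a limit of the assay.
- Compound 3 `COc1cc(Oc2cccc(Nc3ccccc3)c2)cc(OC)c1CNCc1ccc(F)cc1`. Compound 3 gives 4220 nM.

Among the measured compounds shown here, compound 3 is therefore the only compound of the three with an actual number; the other two sit at the limit of > 20000 nM in this assay, at which 2 of the 3 values shown sit. Two steps lead to it: an at least 4.7-fold lower number from compound 1 to compound 3 (0.67 log units; beyond the scatter) and an at least 4.7-fold lower number from compound 2 to compound 3 (0.67 log units; beyond the scatter), both at least modest and both beyond the scatter. The step that the two limits leave unreadable from compound 1 to compound 2 cannot be sized, since both of its ends are limits.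

Compound 4 `COc1cc(Oc2cccc(Nc3ccccc3)c2)cc(OC)c1CNCc1ccc(O)cc1` is the next compound. Against compound 3 the change is hydroxy in place of fluoro on an aromatic carbon. For the measured compounds named here, none of the measured steps concern this position: all three alter the group on the amine nitrogen or the amine itself, not a substituent on the benzyl ring. Going by the values given here, the step from compound 2 to compound 3 shows only that the 4-fluorobenzyl group as a whole brought the number down; it does not separate the part played by the fluoro. Among the compounds with values here, with no step on point, the expectation is a step within the scatter, a 1.3-fold higher number from compound 3 to compound 4 (0.12 log units; within the scatter), in either direction. Compound 4 is therefore expected to give about 5500 nM, with a range from 2000 nM to 15000 nM.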

Compound 4, half-maximal inhibitory concentration: 3360 nM
The estimate for compound 4 lay 1.6-fold (0.21 log units) above the measured number; measured number inside the range.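

In this assay, hydroxy in place of fluoro on an aromatic carbon para to a large group gives a 1.3-fold lower number from compound 3 to compound 4 (0.10 log units; within the scatter), so at this position the two groups cannot be told apart, even though the hydroxy brings a hydrogen-bond donor and a hydrogen-bond acceptor that the fluoro does not. The earlier compounds shown here tied the gain only to the 4-fluorobenzyl group as a whole, whereas compound 4 shows that the fluoro is not needed for it: the 4-hydroxybenzyl group also gives an at least 5.9-fold lower number from compound 2 to compound 4 (0.77 log units; beyond the scatter) and an at least 5.9-fold lower number from compound 1 to compound 4 (0.77 log units; beyond the scatter). Both of these steps start from a limit and not from a number, so they give only a smallest possible size: the limit of > 20000 nM in this assay, at which 2 of the 4 values shown sit.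

On these data alone, what remains open is whether this position needs a substituent at all, and how a plain benzyl group, or a methoxy, an amine or a carboxylic acid at the same place, would read in this assay. Also open, as far as these compounds go, is how a longer chain between the amine nitrogen and the ring, such as 2-phenylethyl, would compare with the 4-fluorobenzyl and 4-hydroxybenzyl groups.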